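Ethyl on the saturated chain carbon across two cores

A few compounds are considered here, and "the series" means these few. Any claim that something is new, unique, unknown or untested is made for them only; others in the source may bear on it.

Compound 1 `CC1C(=O)c2nc(CN3N=C(Cl)CCC3=O)[nH]c2N(C)C1=O`, compound 2 `CC1C(=O)c2nc(CCCN3N=C(Cl)CCC3=O)[nH]c2N(C)C1=O` and compound 3 `CCCC1C(=O)c2nc(CN3N=C(Cl)CCC3=O)[nH]c2N(C)C1=O` have been measured in an assay on isolated protein for binding affinity to adenosine receptor A1 (Homo sapiens); on this read-out lower numbers stand for stronger inhibition and higher numbers for weaker inhibition. For compound 1 the assay reports only a limit, > 100000 nM, which is the limit of > 100000 nM in this assay, at which 1 of the 3 values shown sits. In this assay compound 3 gives 9200 nM. Compound 2 gives 8800 nM, and compound 2 and compound 3 sit within the usual scatter of each other. Among the measured compounds shown here, the one step measured so far is an at least 10-fold lower number from compound 1 to compound 3 (1.03 log units; beyond the scatter), made by ethyl in place of hydrogen on a saturated chain carbon bound to a saturated ring carbon. How the core of compound 2 differs from the core of compound 1 is not broken down here. Compound 4 `CCCC1C(=O)c2nc(CCCN3N=C(Cl)CCC3=O)[nH]c2N(C)C1=O` has not yet been measured; it stands to compound 2 as compound 3 stands to compound 1, through the same change, (ethyl in place of hydrogen on a saturated chain carbon bound to a saturated ring carbon). Beside the measured step, the step from compound 2 to compound 4 is expected to be a 5.9-fold lower number from compound 2 to compound 4 (0.77 log units; beyond the scatter); this expectation rests on the step of an at least 10-fold lower number from compound 1 to compound 3 (1.03 log units; beyond the scatter) and on compound 2 starting from 8800 nM. Compound 4 is estimated at 1500 nM in this assay, between 300 nM and 6000 nM.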

Compound 4, inhibition constant: 1200 nM
Compound 4: the middle estimate sits 1.3-fold (0.10 log units) above what was measured, within the range that was stated.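

In this assay, ethyl in place of hydrogen on a saturated chain carbon bound to a saturated ring carbon carries over to the second core in the same direction, with a 7.3-fold lower number from compound 2 to compound 4 (0.87 log units; beyond the scatter), so two cores shown agree in direction, though two cases make no rule for the whole series. Whether the size of the step also carries over remains unsettled, and the two steps read as follows: the same change on two cores in this assay, an at least 10-fold lower number (1.03 log units; beyond the scatter) from compound 1 to compound 3 and a 7.3-fold lower number (0.87 log units; beyond the scatter) from compound 2 to compound 4; the limit leaves it open whether they differ Compound 1 is held only by a limit of the assay, > 100000 nM.

The compounds shown leave open whether a longer chain such as butyl, or a group of another kind such as an amine or a carboxylic acid, would behave as ethyl does on this saturated chain carbon. They also leave open whether the step seen here would hold on a third core, and whether it says anything about adenosine receptors other than the one read here.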